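Swapping the Nitro Group: What Compound 4 May Show

The source may hold more compounds than are shown below. What is called first, only, known or untested is meant among the compounds shown, and "the series" means these compounds.

Values in a functional assay on NCI-H460 cells (Homo sapiens) for cytotoxicity, read by MTT assay, with a stated time of 72 h; on this read-out higher numbers stand for weaker inhibition and lower numbers for stronger inhibition:
- compound 1 `O=c1[nH]/c(=C\c2ccco2)c(=O)[nH]/c1=C\c1cccc(Oc2ccc(F)cc2)c1`: 155 nM
- compound 2 `O=c1[nH]/c(=C\c2ccc(Br)o2)c(=O)[nH]/c1=C\c1cccc(Oc2ccc(F)cc2)c1`: 361 nM
- compound 3 `O=c1[nH]/c(=C\c2ccc([N+](=O)[O-])o2)c(=O)[nH]/c1=C\c1cccc(Oc2ccc(F)cc2)c1`: > 1000 nM (a limit, not a number)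

Compound 3 stands at the limit of > 1000 nM in this assay, at which 1 of the 3 values shown sits. It is the weakest of the three, and only a limit is known for it.

Compound 4 `CC(C)(C)S(=O)(=O)OCc1ccc(/C=c2\[nH]c(=O)/c(=C/c3cccc(Oc4ccc(F)cc4)c3)[nH]c2=O)o1` keeps the shared core and changes one group: (((tert-butyl)sulfonyl)oxy)methyl in place of nitro on an aromatic carbon. In words, (((tert-butyl)sulfonyl)oxy)methyl comes in place of nitro on an aromatic carbon.

For the measured compounds named here, three measured steps bear on this, all at that same carbon. Bromo in place of hydrogen gives a 2.3-fold higher number from compound 1 to compound 2 (0.37 log units; beyond the scatter). Nitro in place of hydrogen gives an at least 6.4-fold higher number from compound 1 to compound 3 (0.80 log units; beyond the scatter). Nitro in place of bromo gives an at least 2.7-fold higher number from compound 2 to compound 3 (0.44 log units; beyond the scatter).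

Going by the values given here, none of the measured compounds carries a group like the incoming one, so the expectation is loose. From a 2.3-fold higher number from compound 1 to compound 2 (0.37 log units; beyond the scatter) and an at least 6.4-fold higher number from compound 1 to compound 3 (0.80 log units; beyond the scatter), compound 4 is expected to remain weak, with a modest drop in the number at best.

The estimated change is an at least 1.4-fold lower number from compound 3 to compound 4 (0.15 log units; that floor lies within the scatter).

Compound 4 is estimated at 700 nM, within an expected range of 200 nM to 2000 nM.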

Compound 4, half-maximal inhibitory concentration: 378 nM
Compound 4: the middle estimate sits 1.9-fold (0.27 log units) above what was measured; the measured number falls inside the stated range.
By their numbers in this assay, from the lowest: compound 1; then compounds 2 and 4 (each within the scatter of the next). At a limit, above all of these: compound 3.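

In this assay, putting (((tert-butyl)sulfonyl)oxy)methyl in place of nitro on this carbon gives an at least 2.6-fold lower number from compound 3 to compound 4 (0.42 log units; beyond the scatter), so the much bigger group in compound 4 does not carry the penalty seen with nitro. Set against the smaller groups, the same group gives a 1.0-fold higher number from compound 2 to compound 4 (0.02 log units; within the scatter) in place of bromo and a 2.4-fold higher number from compound 1 to compound 4 (0.39 log units; beyond the scatter) in place of hydrogen, which puts it level with bromo while hydrogen still gives the lowest number of the four compounds. The first of these steps has only a floor, and compound 3 is known only as a limit: the limit of > 1000 nM in this assay, at which 1 of the 4 values shown sits.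

The compounds shown leave open how a simple chain at this carbon, such as hydroxymethyl or aminomethyl, would compare with compound 4. Also open, from the compounds shown here alone, is whether a carboxylic acid or any other group here could give a lower number than compound 1.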